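The source may report more compounds than this note shows. Statements on the series, on what has been measured and on what is new or still open speak of the compounds shown alone.

Measured compounds:
- compound 1 `Cc1ccccc1CNC(=O)Oc1ccc(C2=NCCS2)cc1`: 62 nM
- compound 2 `COc1ccc(CNC(=O)Oc2ccc(C3=NCCS3)cc2)cc1`: 320 nM

In an assay on cell membranes (strain Wistar) for inhibition of Fatty-acid amide hydrolase 1 (Rattus norvegicus), read by scintillation counting (on this read-out higher numbers stand for weaker inhibition and lower numbers for stronger inhibition), compound 1 gives 62 nM, the lowest of the two numbers. Its nearest neighbour is compound 2, which in this assay gives 320 nM. Going by the values given here, the only measured step is a 5.2-fold higher number from compound 1 to compound 2 (0.71 log units; beyond the scatter), and it concerns the group on the saturated chain carbon bound to the amide-type nitrogen, not the ring at the other end of the shared core.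

The unmeasured compound 3 `Cc1ccccc1CNC(=O)Oc1ccc(C2=NCCO2)cc1` differs from compound 1 in a different place: a group of 5 heavy atoms (3 carbon, 1 nitrogen, 1 oxygen; one five-membered non-aromatic ring with 2 hetero atoms) in place of a group of 5 heavy atoms (3 carbon, 1 nitrogen, 1 sulfur; one five-membered non-aromatic ring with 2 hetero atoms), on an aromatic carbon. Among the compounds with values here, no measured step touches this part of the molecule, so nothing in the data shows how large a change of this kind is in this assay. Because the step from compound 1 to compound 2 a 5.2-fold higher number from compound 1 to compound 2 (0.71 log units; beyond the scatter) shows that even a change far from this ring moves the number beyond the scatter, some movement cannot be ruled out, but the direction is not indicated by anything measured.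

Compound 3 is therefore expected to stay close to compound 1, with a step of about a 1.9-fold higher number from compound 1 to compound 3 (0.29 log units; within the scatter) and an estimated value of 120 nM, within a range from 40 nM to 400 nM.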

Compound 3, half-maximal inhibitory concentration: 34 nM
Beside the measured number, compound 3's estimate is 3.5-fold (0.55 log units) above it; measured number below the stated range.
By their numbers in this assay, from the lowest: compounds 3 and 1 (each within the scatter of the next); then compound 2.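

In this assay, going by these compounds alone, the step of a 1.8-fold lower number from compound 1 to compound 3 (0.26 log units; within the scatter) gives the first reading at this position, on an aromatic carbon para to a large group: with oxygen in place of sulfur in the five-membered non-aromatic ring, the number stays within the scatter. The earlier compounds shown here showed only a change at the other end of the shared core, a 5.2-fold higher number from compound 1 to compound 2 (0.71 log units; beyond the scatter), which is printed as beyond the scatter, so the series now has one change that moves the number measurably and one that does not. This exchange keeps the ring size and the counted hydrogen-bond donors and acceptors the same, and nothing shown explains why the number holds.

The compounds shown leave open whether a larger change at this position, such as a six-membered ring, a ring with a nitrogen carrying hydrogen in place of the sulfur, or an open methyl ester, would also stay within the scatter. They also leave open whether the 4-methoxyphenyl group would move the number as far on the oxygen-containing ring as it does on the sulfur-containing one.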